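The source may hold more compounds than are shown below. What is called first, only, known or untested is meant among the compounds shown, and "the series" means these compounds.

Measured so far:
compound 1 `ClCc1ccc(Cn2cnc3c(Cl)ncnc32)cc1` — 36300 nM
compound 2 `ClCc1ccccc1Cn1cnc2c(Cl)nc(Cl)nc21` — 6310 nM

Both numbers come from a functional assay on DU-145 cells (Homo sapiens) for cytotoxicity, read by sulforhodamine B assay, with a stated time of 48 h; on this read-out lower numbers stand for higher toxicity in this test and higher numbers for lower toxicity in this test. For the measured compounds named here, compound 2 gives the lower of the two numbers, and the gap to compound 1 lies beyond the scatter; with only two compounds of different substitution at more than one position, nothing further can be drawn from that pair.

The next compound, compound 3 `ClCc1ccccc1Cn1cnc2c(Cl)ncnc21`, keeps the chloromethyl-benzyl part of compound 2 and changes only the core: hydrogen in place of chloro on an aromatic carbon. Going by the values given here, no measured pair isolates this single change, so its direction in this assay is not known from the data. Among the compounds with values here, the only guide is that compound 2, the compound carrying two chloro groups, has the lower number so far, and that compound 1, which carries one chloro group on the core, gives 36300 nM. On that basis a modest loss is expected, though a step no larger than the scatter is also plausible. The expected step is a 1.9-fold higher number from compound 2 to compound 3 (0.28 log units; within the scatter). For compound 3 the estimate is 12000 nM, with a range of 4000 nM to 40000 nM.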

Compound 3, concentration lethal to 50% of the cells: > 100000 nM
Compound 3: only a limit was reported; the forecaster's own chance of this, stated with the estimate: 10%; at least 8.3-fold (0.92 log units) between middle value and limit.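

In this assay, for the compounds shown here, the chloro on the aromatic carbon between two ring nitrogen atoms is the first single place with a readable step: hydrogen in place of chloro gives an at least 15-fold higher number from compound 2 to compound 3 (1.19 log units; beyond the scatter), which is large and beyond the scatter. The value of compound 3, > 100000 nM, is a limit of the assay and not a number. The step therefore marks a minimum for this change in this pair and does not give its full size, because the reading of compound 3 is a limit: the limit of > 100000 nM in this assay, at which 1 of the 3 values shown sits.

Only chloro and hydrogen are shown on this carbon, so it remains open whether an amine, a methoxy group or a bromo group there would give a number closer to that of the chloro compound or to that of the hydrogen compound. The chloromethyl group is present in all three compounds, which leaves open what a plain methyl or a hydroxymethyl group in its place would do to the number in this assay.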